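The source may report more compounds than this note shows. Statements on the series, on what has been measured and on what is new or still open speak of the compounds shown alone.

Measured in a functional assay on HCC827 cells (Homo sapiens) for antiproliferative activity, read by MTT assay, with a stated time of 72 h; a lower number here means a stronger inhibitor, a higher number a weaker inhibitor:
- compound 1 `CC(C)n1c(Sc2ccccc2)nc2cnc(Nc3ccc(N4CCN(C)CC4)cc3)nc21`: 290 nM
- compound 2 `CN(C)CCN(C)c1ccc(Nc2ncc3nc(Sc4ccccc4)n(C4CCOCC4)c3n2)cc1`: 499 nM
- compound 3 `CN(C)C1CCN(c2ccc(Nc3ncc4nc(Sc5ccccc5)n(C5CCOCC5)c4n3)cc2)CC1`: 29.4 nM

Compound 1 lies within the scatter of compound 2, while compound 3 has a lower number, beyond the scatter. Compound 4 `CN1CCN(c2ccc(Nc3ncc4nc(Sc5ccccc5)n(C5CC5)c4n3)cc2)CC1` departs from compound 1 by cyclopropyl in place of isopropyl on an aromatic nitrogen, with cyclopropyl in place of isopropyl on an aromatic nitrogen. Among the measured compounds shown here, the only measured step, a 17-fold lower number from compound 2 to compound 3 (1.23 log units; beyond the scatter), is a change on an aromatic carbon, so it does not bear on this nitrogen. For the measured compounds named here, no measured step isolates this nitrogen. In this assay, no step beyond the scatter is expected, and no direction is favoured. The expected step is a 1.0-fold higher number from compound 1 to compound 4 (0.01 log units; within the scatter). Compound 4 is estimated at 300 nM, with an expected range of 100 nM to 900 nM.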

Compound 4, half-maximal inhibitory concentration: 305 nM
Compound 4: the middle estimate sits 1.0-fold (0.01 log units) below what was measured; the range from low to high includes it.
By their numbers in this assay, from the lowest: compound 3; then compounds 1, 4 and 2 (each within the scatter of the next).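

In this assay, among the compounds shown here, cyclopropyl in place of isopropyl on the aromatic nitrogen gives a 1.1-fold higher number from compound 1 to compound 4 (0.02 log units; within the scatter), the only measured step that isolates this nitrogen. Here, closing the three carbons into a three-membered ring leaves the number within the scatter. No supporting measurement bears on this result.

Open, going by these compounds, is whether a longer chain, a cyclohexyl group or a chain ending in a carboxylic acid on this nitrogen would keep the number in this range. Also open, on these data alone, is whether the step carries over to compounds bearing 4-(dimethylamino)piperidin-1-yl.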